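A few compounds are considered here, and "the series" means these few. Any claim that something is new, unique, unknown or untested is made for them only; others in the source may bear on it.

Compound 3 `Nc1nc2cc(-c3nn(CCC(=O)NO)c4ncnc(N)c34)ccc2o1` stands only at a limit in a functional assay on A549 cells (Homo sapiens) for inhibition, read by MTT assay, with a stated time of 72 h (a higher number here means a weaker inhibitor, a lower number a stronger inhibitor), > 150000 nM. Compound 2 `Nc1ncnc2c1c(-c1cnc3[nH]ccc3c1)nn2CC(=O)NO` is also only a limit, > 150000 nM. Compound 1 `CNC(=O)CCCCCCCn1nc(-c2cnc3[nH]ccc3c2)c2c(N)ncnc21` gives a number in this assay, 51000 nM. Compound 4 `Nc1nc2cc(-c3nn(CCCCCC(=O)NO)c4ncnc(N)c34)ccc2o1` differs from compound 3 by 3-(hydroxycarbamoyl)propyl in place of hydroxycarbamoyl on a saturated chain carbon, two bonds along the chain from an aromatic nitrogen. For the measured compounds named here, one measured step bears on this, an at least 2.9-fold higher number from compound 1 to compound 2 (0.46 log units; beyond the scatter), where the shorter side chain also carries a different end group. Read in reverse, that step suggests a lower number with the longer chain, of at least modest size. The expected step in this assay is an at least 5.0-fold lower number from compound 3 to compound 4 (0.69 log units; beyond the scatter). For compound 4 the estimated value is 30000 nM, with an expected range of 5000 nM to 130000 nM.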

Compound 4, half-maximal inhibitory concentration: > 100000 nM
Compound 4 gave a limit, no number; the forecaster's own chance of this, stated with the estimate: 25%; middle value at least 3.3-fold (0.52 log units) from the limit.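

In this assay compound 3 is only a limit (> 150000 nM). For the compounds shown here, compound 4 is also only a limit (> 100000 nM), so no step between these two compounds can be read. As far as these compounds go, whether 3-(hydroxycarbamoyl)propyl in place of hydroxycarbamoyl changes the value at all remains open.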